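Solubility notes: compound 3 to compound 4

The source may hold more compounds than are shown below. What is called first, only, known or untested is meant among the compounds shown, and "the series" means these compounds.

Within the data shown here, compound 3 `Cc1nn(-c2ccccc2)c2nc(-c3ccc(C(C)C)cc3)c(C#N)c(-c3ccccc3O)c12` gives 9800 nM in a physicochemical assay for solubility, read by spectrophotometry, in phosphate buffer, with a stated time of 18 h, at pH 7.4 (on this read-out higher numbers stand for higher solubility and lower numbers for lower solubility), the second highest of the three numbers so far; compound 2 `CCc1ccc(-c2nc3c(c(C)nn3-c3ccccc3)c(-c3ccccc3C(=O)OC)c2C#N)cc1` at 17000 nM sits within the scatter of it, while compound 1 `CCc1ccc(-c2nc3c(c(C)nn3-c3ccccc3)c(-c3ccccc3S(C)(=O)=O)c2C#N)cc1` at 2200 nM lies beyond the scatter below it. Compound 4 `CCc1cccc(-c2nc3c(c(C)nn3-c3ccccc3)c(-c3ccccc3O)c2C#N)c1` differs from compound 3 by 3-ethylphenyl in place of 4-isopropylphenyl on an aromatic carbon. Among the measured compounds shown here, the only measured step, a 7.7-fold higher number from compound 1 to compound 2 (0.89 log units; beyond the scatter), concerns a different position and does not bear on this change; no measured pair tests the 3-ethylphenyl against the 4-isopropylphenyl. With nothing to guide the direction, compound 4 is expected to give roughly 12000 nM in this assay, between 5000 nM and 30000 nM, a step of a 1.2-fold higher number from compound 3 to compound 4 (0.09 log units; within the scatter) that is expected to stay within the scatter.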

Compound 4, solubility: 11000 nM
The estimate for compound 4 lay 1.1-fold (0.04 log units) above the measured number, and the stated range covers the measured number.
By their numbers in this assay, from the lowest: compound 1; then compounds 3, 4 and 2 (each within the scatter of the next).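

In this assay the change to 3-ethylphenyl from 4-isopropylphenyl, on the aromatic carbon next to the ring nitrogen, gives a 1.1-fold higher number from compound 3 to compound 4 (0.05 log units; within the scatter) and stays within the scatter. Among these compounds, this is the first measured step at this position, and the read-out does not separate the two groups. They differ in both chain and point of attachment, and this single pair cannot tell those two changes apart. No measurement on hand explains the result. As far as these compounds go, whether an amine, a carboxylic acid or a longer chain on this phenyl ring would shift the number remains open.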